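The compounds below may be only part of what the source reports. "The series", "measured", "known", "first", "only" and "open" are said of these compounds alone.

Measured compounds in this study:

Compound 1, `CC1(Cc2ccccc2)CC(S(=O)(=O)c2ccc(Nc3ccc(/C(N)=N/O)cc3)cc2)=C(c2ccc(/C(N)=N/O)cc2)O1`: 47600 nM
Compound 2, `CC1(Cc2ccccc2)CC(S(=O)(=O)c2ccc(/C(N)=N/O)cc2)=C(c2ccc(Nc3ccc(/C(N)=N/O)cc3)cc2)O1`: 9800 nM
Compound 3, `CC1(Cc2ccccc2)CC(S(=O)(=O)c2ccc(Nc3cccc(/C(N)=N/O)c3)cc2)=C(c2ccc(/C(N)=N/O)cc2)O1`: 46600 nM

All three were tested in an ADME assay on THP-1 cells (Homo sapiens) for cytotoxicity, read by flow cytometry, with a stated time of 72 h; a higher number here means a weaker inhibitor, a lower number a stronger inhibitor. Compound 1 gives 47600 nM, while compound 3 gives 46600 nM. Compound 3 differs from compound 1 by a group of 10 heavy atoms (7 carbon, 2 nitrogen, 1 oxygen; one six-membered aromatic ring of carbon only) in place of a group of 10 heavy atoms (7 carbon, 2 nitrogen, 1 oxygen; one six-membered aromatic ring of carbon only), on a nitrogen on an aromatic ring, and this change gave a 1.0-fold lower number from compound 1 to compound 3 (0.01 log units; within the scatter). Compound 2 gives 9800 nM, the lowest of the three numbers. The difference between the cores of compound 1 and compound 2 is not broken down here.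

Compound 4, `CC1(Cc2ccccc2)CC(S(=O)(=O)c2ccc(/C(N)=N/O)cc2)=C(c2ccc(Nc3cccc(/C(N)=N/O)c3)cc2)O1`, has not yet been measured. It differs from compound 2 by a group of 10 heavy atoms (7 carbon, 2 nitrogen, 1 oxygen; one six-membered aromatic ring of carbon only) in place of a group of 10 heavy atoms (7 carbon, 2 nitrogen, 1 oxygen; one six-membered aromatic ring of carbon only), on a nitrogen on an aromatic ring, the same change as from compound 1 to compound 3. Because the earlier step gave a 1.0-fold lower number from compound 1 to compound 3 (0.01 log units; within the scatter), a similarly small step is expected here: a 1.0-fold higher number from compound 2 to compound 4 (0.01 log units; within the scatter). Compound 4 is therefore estimated at 10000 nM, most likely between 4000 nM and 25000 nM.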

Compound 4, half-maximal inhibitory concentration: 44000 nM
Compound 4: middle estimate off by 4.4-fold (0.64 log units), on the low side, and the stated range ends below it.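

In this assay the swap on the nitrogen on an aromatic ring gave a 4.5-fold higher number from compound 2 to compound 4 (0.65 log units; beyond the scatter) and so did not carry over unchanged from one core to the other: the same change on two cores in this assay, a 1.0-fold lower number (0.01 log units; within the scatter) from compound 1 to compound 3 and a 4.5-fold higher number (0.65 log units; beyond the scatter) from compound 2 to compound 4, 4.6-fold (0.66 log units) apart, beyond the scatter of two such steps. The same swap can therefore have a small effect on one core and a clear effect on another, so the earlier step alone was a poor guide here. This does not show why the two cores differ, and two pairs cannot predict the size of the step on any further core.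

As far as these compounds go, it remains open whether a third core would follow the step seen on the core of compound 1 or the one seen on the core of compound 2. From the compounds shown here alone, it also remains open how a group bearing a carboxylic acid would behave in the same place on these two cores.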